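Taking the hydroxy group off compound 1

This account rests on a few compounds, and the source may have more. Where it says the series, first, only, none or still open, it means among the compounds named here.

Measured so far in a functional assay on A2780 cells (Homo sapiens) for inhibition, with a stated time of 72 h; a higher number here means a weaker inhibitor, a lower number a stronger inhibitor:
compound 1 `CN1c2ccc(NC(=S)Nc3ccc([N+](=O)[O-])cc3)cc2C(C)(C)C(O)C1(C)C`: 10000 nM
compound 2 `CN1c2ccc(NC(=S)Nc3ccc(C(F)(F)F)cc3)cc2C(C)(C)C(O)C1(C)C`: 7600 nM

Compound 1 has a single measured neighbour, and the two values cannot be ranked. Among the measured compounds shown here, the only measured step, a 1.3-fold lower number from compound 1 to compound 2 (0.12 log units; within the scatter), puts trifluoromethyl in place of nitro on an aromatic carbon, so it does not speak directly to the change considered here. Compound 3 `CN1c2ccc(NC(=S)Nc3ccc([N+](=O)[O-])cc3)cc2C(C)(C)CC1(C)C` keeps the nitro group but differs from compound 1 as follows: hydrogen in place of hydroxy on a saturated ring carbon. For the measured compounds named here, no measured step touches this hydroxy, so in this assay no shift beyond the scatter can be expected, in either direction, though the uncertainty is wide. The expected step is a 1.3-fold lower number from compound 1 to compound 3 (0.10 log units; within the scatter). For compound 3 the estimated value is 8000 nM, with a range of 2500 nM to 25000 nM.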

Compound 3, half-maximal inhibitory concentration: 4500 nM
The estimate for compound 3 lay 1.8-fold (0.25 log units) above the measured number, within the range that was stated.
By their numbers in this assay, from the lowest: compounds 3, 2 and 1 (each within the scatter of the next, the first and the last beyond it).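

Among the compounds shown here, replacing the hydroxy group with hydrogen on this saturated ring carbon gives the first step beyond the scatter in this assay, with a 2.2-fold lower number from compound 1 to compound 3 (0.35 log units; beyond the scatter) as a modest gain in potency. The hydroxy group is therefore not needed for the activity seen in compound 1, and losing it does not weaken the compound. Nothing at hand explains the shift.

From the compounds shown here alone, whether an amine or a methoxy group on this carbon would hold or move the number stays open. Also open, going by these compounds, is whether the same step would appear with trifluoromethyl in place of nitro, as in compound 2.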